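Series notes: distal aryl change from compound 3 to compound 4

The source may hold more compounds than are shown below. What is called first, only, known or untested is meant among the compounds shown, and "the series" means these compounds.

Compound 1 `COC(=O)/C=C/c1cccc(N(Cc2ccc(/C=C/c3cc(C(F)(F)F)cc(C(F)(F)F)c3)cc2)C(=O)C(C)C)c1` gives 1950 nM in an assay on isolated protein with Bile acid receptor (Homo sapiens) as the target; a lower number here means that less compound is needed, a higher number that more compound is needed for the effect. For the measured compounds named here, compound 2 `COC(=O)/C=C/c1cccc(N(Cc2ccc(/C=C/c3c(C)cc(C)cc3C)cc2)C(=O)C(C)C)c1` gives 149 nM, and compound 3 `COC(=O)/C=C/c1cccc(N(Cc2ccc(/C=C/c3c(C)cc(C)cc3C)cc2)C(=O)NC(C)C)c1` gives 431 nM, the second highest of the three numbers; the one measured step, a 2.9-fold higher number from compound 2 to compound 3 (0.46 log units; beyond the scatter), is modest. Compound 4 `COC(=O)/C=C/c1cccc(N(Cc2ccc(-c3ccc(N(C)C)cc3)cc2)C(=O)NC(C)C)c1` carries the change (4-(dimethylamino)phenyl in place of 2-(2,4,6-trimethylphenyl)ethenyl on an aromatic carbon). Going by the values given here, no measured step alters the distal ring or its linker; compound 1 and compound 2 differ only in the groups on that ring, and their numbers lie far apart, so changes in this region can move the number well beyond the scatter. Direction is not fixed by any step; the estimate leans toward a higher number. Compound 4 is expected at 1500 nM, between 400 nM and 6000 nM, a step of a 3.5-fold higher number from compound 3 to compound 4 (0.54 log units; beyond the scatter).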

Compound 4, half-maximal effective concentration: 162 nM
Estimate against measurement, compound 4: 9.3-fold (0.97 log units) above; measured number outside the range, below it.
By their numbers in this assay, from the lowest: compounds 2 and 4 (each within the scatter of the next); then compound 3; then compound 1.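

In this assay, 4-(dimethylamino)phenyl in place of 2-(2,4,6-trimethylphenyl)ethenyl gives a 2.7-fold lower number from compound 3 to compound 4 (0.42 log units; beyond the scatter), a modest step. The earlier compounds shown here kept the double bond outside aromatic rings, whereas compound 4 shows that this position accepts a ring placed directly on the aromatic carbon, without that double bond. Nothing available explains this step.

The linker and the ring substituents change together here, so their separate contributions remain unresolved. A directly attached 2,4,6-trimethylphenyl or an unsubstituted phenyl at this position would help to separate them.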